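Swapping Nitro for Cyano on a Weak Cytotoxic Triazole

The compounds below may be only part of what the source reports. "The series", "measured", "known", "first", "only" and "open" are said of these compounds alone.

Three measured compounds share one core and differ only in the group on the outer ring. Compound 1 `O=c1ccoc2cc(OCc3cn(Cc4cccc(Br)c4)nn3)ccc12` was tested in a functional assay on MDA-MB-231 cells (Homo sapiens) for cytotoxicity, read by MTT assay, with a stated time of 48 h; a higher number here means a weaker inhibitor, a lower number a stronger inhibitor; compound 1 gives > 100000 nM, which is a limit of the assay and not a number. Compound 2 `CC(C)(C)c1ccc(Cn2cc(COc3ccc4c(=O)ccoc4c3)nn2)cc1` likewise gives > 100000 nM, again a limit rather than a number. For the measured compounds named here, compound 3 `O=c1ccoc2cc(OCc3cn(Cc4ccc([N+](=O)[O-])cc4)nn3)ccc12` is the only one with a measured number, giving 71300 nM in this assay. The steps of an at least 1.4-fold lower number from compound 1 to compound 3 (0.14 log units; that floor lies within the scatter) and an at least 1.4-fold lower number from compound 2 to compound 3 (0.14 log units; that floor lies within the scatter) have floors within the scatter, and two of the three values sit at the limit (the limit of > 100000 nM in this assay, at which 2 of the 3 values shown sit), so compound 3 cannot be called stronger than the others.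

Compound 4 `N#Cc1ccc(Cn2cc(COc3ccc4c(=O)ccoc4c3)nn2)cc1` differs from compound 3 by cyano in place of nitro on an aromatic carbon. Going by the values given here, no measured step covers this exact swap; the two measured steps only show that changing the group on that ring moved the number little, if at all. This step in this assay is therefore expected to be small, a 1.2-fold higher number from compound 3 to compound 4 (0.08 log units; within the scatter), with no clear direction. Compound 4 is estimated at 85000 nM, between 35000 nM and 200000 nM, in this assay.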

Compound 4, half-maximal inhibitory concentration: > 100000 nM
Compound 4 was reported as a limit; the forecaster's own chance of this, stated with the estimate: 40%; middle value at least 1.1-fold (0.07 log units) from the limit.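

In this assay, the change from 4-nitrophenyl to 4-cyanophenyl gives an at least 1.4-fold higher number from compound 3 to compound 4 (0.14 log units; that floor lies within the scatter), so this swap cannot be told apart from no change at all. Compound 4 now stands with compound 1 and compound 2 at one shared limit of the assay, which is not a number: the limit of > 100000 nM in this assay, at which 3 of the 4 values shown sit. The steps from compound 1 and from compound 2 to compound 4 cannot be read, as each joins two limits, so compound 3 remains the only compound with a number and no order can be set among the outer-ring groups shown.

From the compounds shown here alone, it remains open whether any group at this place can bring a clear, measurable gain in this assay. For the compounds shown here, an amine or a carboxylic acid on that aromatic carbon would test this, and a number well clear of the limit would give the first readable step here.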